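The source may report more compounds than this note shows. Statements on the series, on what has been measured and on what is new or still open speak of the compounds shown alone.

In a toxicity assay on CCRF-CEM cells (Homo sapiens) for cytotoxicity (on this read-out lower numbers stand for higher toxicity in this test and higher numbers for lower toxicity in this test), compound 1 `COC(=O)c1cccc2c1nc(-c1c(F)cccc1F)n2Cc1c(F)cccc1F` gives 57.7 uM. Putting hydroxy in place of its methoxycarbonyl gives compound 2 `Oc1cccc2c1nc(-c1c(F)cccc1F)n2Cc1c(F)cccc1F`. Compound 2 reads > 100 uM, which is a limit of the assay and not a number, so its place is known only as the limit of > 100 uM in this assay, at which 1 of the 2 values shown sits. The next structure, compound 3 `Fc1cccc(F)c1Cn1c(-c2c(F)cccc2F)nc2c(Cl)cccc21`, has chloro in place of hydroxy on an aromatic carbon. Among the measured compounds shown here, only one measured step bears on this change, because it alters the group on that same carbon: an at least 1.7-fold higher number from compound 1 to compound 2 (0.23 log units; that floor lies within the scatter). That step gives no sign of a large effect, so no large step is expected in this assay. Any expected move is towards a lower number, since compound 2 has only a limit. The estimated change is an at least 1.5-fold lower number from compound 2 to compound 3 (0.18 log units; that floor lies within the scatter). Compound 3 is expected at 65 uM, with an estimated range from 25 uM to 100 uM.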

Compound 3, half-maximal toxic concentration: 30.4 uM
Compound 3: the middle estimate sits 2.1-fold (0.33 log units) above what was measured, within the range that was stated.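

Among the compounds shown here, on this aromatic carbon, chloro is the first group to separate clearly from another in this assay, with an at least 3.2-fold lower number from compound 2 to compound 3 (0.51 log units; beyond the scatter). The reading for compound 2 is a limit, so this step is only a floor and the real gap between hydroxy and chloro could be larger: the limit of > 100 uM in this assay, at which 1 of the 3 values shown sits. Chloro against methoxycarbonyl gives a 1.9-fold lower number from compound 1 to compound 3 (0.28 log units; within the scatter), so these two groups cannot be told apart in this test, even though one is a single atom and the other a larger group.

The compounds shown leave open how an amine or a carboxylic acid on this same carbon would read, and whether either would fall closer to hydroxy or to chloro and methoxycarbonyl. They also leave open whether bromo would behave like chloro, as a single chloro compound cannot show a trend.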